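A few compounds are considered here, and "the series" means these few. Any claim that something is new, unique, unknown or untested is made for them only; others in the source may bear on it.

Measured so far in an ADME assay on PBMC cells (Homo sapiens) for cytotoxicity (on this read-out higher numbers stand for lower toxicity in this test and lower numbers for higher toxicity in this test), each value a limit of the assay:

- Compound 1 `CCCCCC(=O)Nc1nc(N)nc2c1ncn2[C@H]1CO[C@@H](CO)O1`: > 100000 nM
- Compound 2 `CCCCCCCC(=O)Nc1nc(N)nc2c1ncn2[C@H]1CO[C@@H](CO)O1`: > 100000 nM
- Compound 3 `CCCCCCCCCC(=O)Nc1nc(N)nc2c1ncn2[C@H]1CO[C@@H](CO)O1`: > 100000 nM

Compound 3 offers no exact number as a starting point. Its value of > 100000 nM is only a limit. The whole series sits at the limit of > 100000 nM in this assay, at which 3 of the 3 values shown sit.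

Compound 4 `CCCCCCCCCCCC(=O)Nc1nc(N)nc2c1ncn2[C@H]1CO[C@@H](CO)O1` differs from compound 3 by ethyl in place of hydrogen on a saturated chain carbon, nine bonds along the chain from a carbonyl carbon. In words, this is ethyl in place of hydrogen on a saturated chain carbon, nine bonds along the chain from a carbonyl carbon.

The closest precedents are a step that the two limits leave unreadable from compound 1 to compound 2 and a step that the two limits leave unreadable from compound 2 to compound 3, which add the same ethyl at earlier places on the chain. The larger change, a step that the two limits leave unreadable from compound 1 to compound 3, bears on it too. None of these steps has a readable size, so they predict neither a direction nor a magnitude in this assay.

The expected outcome is a number no higher from compound 3 to compound 4 (the limit leaves the size open), with no readable change the likeliest result. For compound 4 the estimate is 100000 nM, with an expected range of 40000 nM to 100000 nM.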

Compound 4, half-maximal cytotoxic concentration: 60000 nM
Compound 4: middle estimate off by 1.7-fold (0.22 log units), on the high side, and the stated range covers the measured number.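

In this assay, within the data shown here, compound 4 is the first with an exact number rather than a limit, so adding ethyl on a saturated chain carbon, nine bonds along the chain from a carbonyl carbon, gives the first step with a readable size, though only as a floor. The comparison gives an at least 1.6-fold lower number from compound 3 to compound 4 (0.22 log units; that floor lies within the scatter), and the same floor appears in the two wider comparisons, an at least 1.6-fold lower number from compound 2 to compound 4 (0.22 log units; that floor lies within the scatter) and an at least 1.6-fold lower number from compound 1 to compound 4 (0.22 log units; that floor lies within the scatter), so none of them shows a change beyond the scatter. The steps among the three shorter-chain compounds cannot be read, and those compounds share one limit: the limit of > 100000 nM in this assay, at which 3 of the 4 values shown sit.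

Going by these compounds, the true distance between compound 4 and the compounds held at that limit remains unknown. Also open, on these data alone, is whether a longer chain would move the number clearly, or what an amine or a carboxylic acid in place of this ethyl would do.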